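A few compounds are considered here, and "the series" means these few. Any claim that something is new, unique, unknown or untested is made for them only; others in the source may bear on it.

Compound 3 `CN(C)CCCNc1nc(NCc2ccco2)c2ccccc2n1` carries a 3-(dimethylamino)propyl side chain, and in a functional assay on DU-145 cells (Homo sapiens) for cytotoxicity, read by MTT assay, with a stated time of 2 days, tested at 10 uM (on this read-out higher numbers stand for more inhibition at the one concentration tested (going by the name of the read-out) and lower numbers for less inhibition), compound 3 is recorded as "not determined" (no result reported), so it offers no number to stand on. Compound 4 `CCN(CC)CCNc1nc(NCc2ccco2)c2ccccc2n1` differs from it by diethylamino in place of (dimethylamino)methyl on a saturated chain carbon, two bonds along the chain from a nitrogen on an aromatic ring. Going by the values given here, the only measured guide is the pair of compound 1 `CN(C)CCNc1nc(NCc2ccco2)c2ccccc2n1` and compound 2 `c1coc(CNc2nc(NCCCN3CCCC3)nc3ccccc23)c1`: in this assay compound 1 gives 20% and compound 2 gives 40.1%, a step of a number 20.1 percentage points higher from compound 1 to compound 2 (beyond the scatter) that also alters the amine on the side chain. Compound 4 shares the 2-(dimethylamino)ethyl chain length of compound 1 while carrying a larger amine, as compound 2 does, so a value between those two neighbours is expected. Compound 4 is therefore expected to give about 30% in this assay, within 10% to 55%.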

Compound 4, a percentage reported as inhibition, at one concentration (the size of the read-out at that concentration, not a potency): 28.5%
Beside the measured number, compound 4's estimate is 1.5 percentage points above it, and the stated range covers the measured number.
By their numbers in this assay, from the lowest: compounds 1 and 4 (each within the scatter of the next); then compound 2.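

In this assay, diethylamino does not set itself apart from dimethylamino at this place on the saturated chain carbon, with a number 8.5 percentage points higher from compound 1 to compound 4 (within the scatter). The (pyrrolidin-1-yl)methyl group stays clear of diethylamino, with a number 11.6 percentage points lower from compound 2 to compound 4 (beyond the scatter), so enlarging the open-chain amine does not match what that ring-bearing side chain gives. Nothing measured here explains this difference. As far as these compounds go, it remains open whether a piperidine or morpholine on this chain, or a longer chain ending in diethylamino, would fall with compound 2 or with compound 1 and compound 4.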